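Trading a tert-butyl for a cyclobutyl ring

The compounds below may be only part of what the source reports. "The series", "measured", "known", "first", "only" and "open" are said of these compounds alone.

Within the data shown here, compound 1 `CC(C)(C)CN1CCc2c(sc(NC(=O)Nc3ccc(Cl)cc3)c2C(N)=O)C1` is the only compound here with a numerical result: in a functional assay (strain AB) with Danio rerio as the target, read by microscopy, with a stated time of 1 h (a higher number here means that more compound is needed for the effect, a lower number that less compound is needed), compound 1 gives 5560 nM. Compound 2 `CCC(O)c1cc2c(cc1NC(=O)Nc1ccc(Cl)cc1)OCCO2` in this assay gives > 25000 nM, which is a limit of the assay and not a number. Compound 3 `NC(=O)c1c(NC(=O)Nc2ccc(Cl)cc2)sc2c1CCN(CC1CCC1)C2` has not yet been measured. It differs from compound 1 by cyclobutyl in place of tert-butyl on a saturated chain carbon bound to an amine nitrogen in a ring. Among the measured compounds shown here, no measured step of this kind is available to lean on, so the change is expected to make little difference in this assay. The step of a 1.1-fold lower number from compound 1 to compound 3 (0.05 log units; within the scatter) is expected to stay within the usual scatter. Compound 3 is therefore estimated at 5000 nM, with a range from 2000 nM to 15000 nM.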

Compound 3, half-maximal effective concentration: 1360 nM
Compound 3: middle estimate off by 3.7-fold (0.57 log units), on the high side, outside the stated range (below it).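

In this assay, this change gives a 4.1-fold lower number from compound 1 to compound 3 (0.61 log units; beyond the scatter), so less of compound 3 is needed for the effect. The earlier compounds shown here offered no measured step at this position; now it is clear that the group here matters. Tert-butyl and cyclobutyl both have 4 heavy atoms, so the gain comes without any change in that count.

On these data alone, whether a cyclopentyl ring, a cyclopropyl ring or a longer chain at this place would lower the number further remains open. Nothing measured here explains why the ring gives the lower number.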